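The compounds below may be only part of what the source reports. "The series", "measured", "known", "first", "only" and "open" are said of these compounds alone.

Measured so far:
- Compound 1 `O=C(CCCl)Nc1ccc(I)cc1` — 18000 nM
- Compound 2 `CC(C)(C)c1ccc(NC(=O)CCCl)cc1` — 88000 nM

In a functional assay on HT-29 cells (Homo sapiens) for antiproliferative activity, with a stated time of 48 h (on this read-out lower numbers stand for stronger inhibition and higher numbers for weaker inhibition), compound 2 gives 88000 nM, the highest of the two numbers. Compound 1 gives 18000 nM in this assay, and a 4.9-fold higher number from compound 1 to compound 2 (0.69 log units; beyond the scatter). Compound 3 `CC(C)(C)c1ccc(NC(=O)CCCCl)cc1` differs from compound 2 by chloromethyl in place of chloro on a saturated chain carbon, two bonds along the chain from a carbonyl carbon. Among the measured compounds shown here, the single measured step concerns the aromatic substituent and not the chain, so no measured step bears on this change. No step beyond the scatter is therefore expected in this assay. Compound 3 is estimated at 100000 nM, with a range from 30000 nM to 300000 nM. This estimate means a 1.1-fold higher number from compound 2 to compound 3 (0.06 log units; within the scatter) is expected.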

Compound 3, half-maximal inhibitory concentration: > 100000 nM
Compound 3: no number, only a limit; the forecaster's own chance of this, stated with the estimate: 20%; the middle value sits exactly at the limit.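

In this assay compound 3 gives > 100000 nM, which is a limit and not a number. Chloromethyl in place of chloro on a saturated chain carbon, two bonds along the chain from a carbonyl carbon, is the first change read on the chain, and it shows no lower number with tert-butyl held. The step is an at least 1.1-fold higher number from compound 2 to compound 3 (0.05 log units; that floor lies within the scatter), a floor only, so its real size cannot be read: the limit of > 100000 nM in this assay, at which 1 of the 3 values shown sits.

Going by these compounds, whether the same chain change behaves alike with iodo on the aromatic carbon stays open. So does the effect of an amine in place of chloro on the chain.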